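The source may hold more compounds than are shown below. What is called first, only, known or untested is meant among the compounds shown, and "the series" means these compounds.

Measured in a functional assay on HT-29 cells (Homo sapiens) for cytotoxicity, read by MTT assay, with a stated time of 72 h; on this read-out lower numbers stand for stronger inhibition and higher numbers for weaker inhibition:
- Compound 1 `COc1ccc(NC(=O)CN2CCN(c3nnc(Cc4ccncc4)c4ccccc34)CC2)cc1OC`: 40100 nM
- Compound 2 `O=C(CN1CCN(c2nnc(Cc3ccncc3)c3ccccc23)CC1)Nc1cccc(Br)c1`: 1350 nM
- Compound 3 `O=C(CN1CCN(c2nnc(Cc3ccncc3)c3ccccc23)CC1)Nc1ccc(F)c(C(F)(F)F)c1`: 1110 nM

Compound 3, at 1110 nM, cannot be told apart from compound 2, at 1350 nM, and both stand well under compound 1. Compound 4 `O=C(CN1CCN(c2nnc(Cc3ccncc3)c3ccccc23)CC1)Nc1ccc(F)c(Cl)c1` carries chloro in place of trifluoromethyl on an aromatic carbon, ortho to a fluoro group: chloro in place of trifluoromethyl on an aromatic carbon. The large steps, a 30-fold lower number from compound 1 to compound 2 (1.47 log units; beyond the scatter) and a 36-fold lower number from compound 1 to compound 3 (1.56 log units; beyond the scatter), replace a group that this change leaves out of play. The nearer guide is a 1.2-fold lower number from compound 2 to compound 3 (0.09 log units; within the scatter), which also exchanges one halogen-bearing phenyl for another. In this assay, no step beyond the scatter is therefore expected, and the estimated step is a 1.2-fold higher number from compound 3 to compound 4 (0.07 log units; within the scatter). Compound 4 is estimated at 1300 nM, with an expected range of 500 nM to 3500 nM.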

Compound 4, half-maximal inhibitory concentration: 880 nM
Compound 4: the middle estimate sits 1.5-fold (0.17 log units) above what was measured, and the stated range covers the measured number.
By their numbers in this assay, from the lowest: compounds 4, 3 and 2 (each within the scatter of the next); then compound 1.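

In this assay, chloro can take the place of trifluoromethyl on this aromatic carbon, ortho to a fluoro group, with no step beyond the scatter (a 1.3-fold lower number from compound 3 to compound 4 (0.10 log units; within the scatter)). The 3-chloro-4-fluorophenyl group also stays within the scatter of 3-bromophenyl (a 1.5-fold lower number from compound 2 to compound 4 (0.19 log units; within the scatter)), while its step from 3,4-dimethoxyphenyl is large (a 46-fold lower number from compound 1 to compound 4 (1.66 log units; beyond the scatter)). Nothing available explains why these groups give such close results.

Still open, as far as these compounds go, is whether a nitrile or an amine on this aromatic carbon would stay within the scatter, and what a plain hydrogen there would give.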